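Difluorophenyl for methoxyphenyl: cytotoxicity expected to stay unreadable

This account rests on a few compounds, and the source may have more. Where it says the series, first, only, none or still open, it means among the compounds named here.

Compound 1 `Cc1ccc(NC(=O)CSc2snnc2-c2ccc(F)cc2F)c(Br)c1` shows in an ADME assay on MT4 cells (Homo sapiens) for cytotoxicity (on this read-out higher numbers stand for lower toxicity in this test and lower numbers for higher toxicity in this test), a value of > 273000 nM, which is a limit of the assay rather than a number.
Compound 2 `COc1ccc(-c2nnsc2SCC(=O)Nc2ccccc2Cl)cc1` shows in this assay a value of > 318000 nM, again a limit.
Compound 3 `COc1ccc(-c2nnsc2SCC(=O)Nc2ccccc2[N+](=O)[O-])cc1` shows in this assay a value of >= 280000 nM, also a limit.

So compound 2 stands only at a limit in this assay, and the two further values shown are limits as well. For the measured compounds named here, the one measured step, a step that the two limits leave unreadable from compound 2 to compound 3, is therefore not readable in size. Compound 4 `O=C(CSc1snnc1-c1ccc(F)cc1F)Nc1ccccc1Cl` arises from compound 2 by the change (2,4-difluorophenyl in place of 4-methoxyphenyl on an aromatic carbon). Going by the values given here, no measured step bears directly on this change; the only related observation is that compound 1, which carries the 2,4-difluorophenyl group, sits at the limit of > 273000 nM in this assay, at which 1 of the 3 values shown sits, while compound 2 sits at the limit of > 318000 nM in this assay, at which 1 of the 3 values shown sits, and compound 3 at the limit of >= 280000 nM in this assay, at which 1 of the 3 values shown sits. No readable step is expected from compound 2 to compound 4, so an at least 1.0-fold lower number from compound 2 to compound 4 (0.02 log units; that floor lies within the scatter) is the estimate. Compound 4 is expected to give about 300000 nM in this assay, between 150000 nM and 600000 nM, most likely reported again only as a limit.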

Compound 4, half-maximal cytotoxic concentration: 178000 nM
For compound 4 the middle estimate is 1.7-fold (0.23 log units) above the measured one, within the range that was stated.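

For the compounds shown here, with compound 4, this assay gives its only value shown that is a number rather than a limit. At this position, 2,4-difluorophenyl in place of 4-methoxyphenyl now has a readable lower bound: an at least 1.7-fold lower number from compound 2 to compound 4 (0.25 log units; that floor lies within the scatter). Keeping the 2,4-difluorophenyl group and changing the group on the amide-type nitrogen gives an at least 1.5-fold lower number from compound 1 to compound 4 (0.18 log units; that floor lies within the scatter), so neither floor shows a step beyond the scatter, and the 2,4-difluorophenyl group does not by itself bring the read-out to a number, as compound 1 remains at a limit.

On these data alone, the true size of both steps stays open, and the steps between limits cannot be read. Also open, as far as these compounds go, is how an aminophenyl or a carboxyphenyl group at this position would read in this assay.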